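A few compounds are considered here, and "the series" means these few. Any claim that something is new, unique, unknown or untested is made for them only; others in the source may bear on it.

Of the compounds shown here, two have been measured so far. Compound 1, `CC1=C(/C=C/C(C)=C/C=C/C(C)=C\C(=O)Nc2ccccc2)C(C)(C)CC=C1c1cccnc1`, gives 8320 nM in a functional assay on MCF7 cells (Homo sapiens) for inhibition, read by MTT assay; a higher number here means a weaker inhibitor of growth, a lower number a stronger inhibitor of growth. Compound 2, `CC1=C(/C=C/C(C)=C/C=C/C(C)=C\C(=O)Nc2ccc(F)cc2)C(C)(C)CCC1n1ccnc1`, gives 400 nM in this assay. Of these two numbers, compound 2 has the lower one, and the gap between compound 2 and compound 1 is well beyond the usual scatter of this assay, so compound 2 is the stronger inhibitor of growth of the pair. The two structures differ in several places at once, so no single change can be tied to that gap.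

Compound 3, `CC1=C(/C=C/C(C)=C/C=C/C(C)=C\C(=O)Nc2ccc(O)cc2)C(C)(C)CCC1n1ccnc1`, has not yet been measured. It differs from compound 2 in one place only: hydroxy in place of fluoro on an aromatic carbon. Going by the values given here, no measured pair shows what this exchange does here, so the expectation for compound 3 rests on compound 2 alone. The step from compound 2 to compound 3 is expected to be small, within the scatter, as a 1.1-fold lower number from compound 2 to compound 3 (0.06 log units; within the scatter). Compound 3 is therefore expected to give about 350 nM in this assay, in a range from 80 nM to 1500 nM.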

Compound 3, concentration for 50% growth inhibition: 1990 nM
Beside the measured number, compound 3's estimate is 5.7-fold (0.75 log units) below it; the measured number lies above the stated range.
By their numbers in this assay, from the lowest: compound 2; then compound 3; then compound 1.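

Putting hydroxy in place of fluoro gives a 5.0-fold higher number from compound 2 to compound 3 (0.70 log units; beyond the scatter) in this assay, so growth inhibition weakens by a modest step that lies beyond the usual scatter. Going by these compounds alone, this is the first sign that this place on the six-membered aromatic ring, para to a large group, responds to a small exchange: one heavy atom replaces one heavy atom, yet the entering hydroxy brings 1 hydrogen-bond donor and 1 hydrogen-bond acceptor, while the leaving fluoro counts neither. Nothing available explains why the number rises, and a single exchange cannot show which difference between the two groups matters.

Going by these compounds, with only fluoro and hydroxy compared at this place, it remains open whether methoxy, chloro or an amine would sit closer to compound 2 or to compound 3, and therefore whether the hydrogen-bond counts track the numbers at all. Compound 1 differs from both in more than one place, so it cannot settle this question, and the result is also confined to this one cell-based growth test.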